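From 4-fluorophenyl to 4-methylphenyl: working notes

The source may hold more compounds than are shown below. What is called first, only, known or untested is meant among the compounds shown, and "the series" means these compounds.

Measured in an ADME assay on HCT-116 cells (Homo sapiens) for cytotoxicity, read by CellTiter-Glo, with a stated time of 72 h (on this read-out higher numbers stand for weaker inhibition and lower numbers for stronger inhibition), each value a limit of the assay:
compound 1 `CC1CCN(C2CCN(S(=O)(=O)c3cccc(N)c3)CC2)CC1` gives > 5000 nM
compound 2 `CC1CCN(C2CCN(S(=O)(=O)c3cccc(-c4ccccc4F)c3)CC2)CC1` gives > 5000 nM
compound 3 `CC1CCN(C2CCN(S(=O)(=O)c3cccc(-c4ccc(F)cc4)c3)CC2)CC1` gives > 5000 nM

Compound 3 has no number, only a limit (> 5000 nM). The whole set sits at that same limit (the limit of > 5000 nM in this assay, at which 3 of the 3 values shown sit), so compound 3 cannot be ranked within the series.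

The next structure is compound 4 `Cc1ccc(-c2cccc(S(=O)(=O)N3CCC(N4CCC(C)CC4)CC3)c2)cc1`, which carries methyl in place of fluoro on an aromatic carbon, para to a large group (methyl in place of fluoro on an aromatic carbon). The same difference reads as 4-fluorophenyl to 4-methylphenyl.

For the measured compounds named here, three measured steps bear on this change. The closest is a step that the two limits leave unreadable from compound 2 to compound 3, followed by a step that the two limits leave unreadable from compound 1 to compound 3 and a step that the two limits leave unreadable from compound 1 to compound 2. None of them has a readable size, so they give no direction in this assay, and no step beyond the scatter is expected. The only anchor for the expectation is compound 3 (> 5000 nM), and compound 4 will most likely be reported as a limit too. The expected step is small (a step that the limit leaves unreadable from compound 3 to compound 4). For compound 4 the estimate is 6000 nM, with an expected range from 3000 nM to 12000 nM.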

Compound 4, half-maximal inhibitory concentration: > 5000 nM
Compound 4 ended at the assay's limit; the forecaster's own chance of this, stated with the estimate: 85%; the middle value lies beyond the limit too.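

In this assay compound 4 gives > 5000 nM as a limit of the assay and not a number. No step between compound 4 and compound 1, compound 2 or compound 3 can be read, because all four compounds share one limit: the limit of > 5000 nM in this assay, at which 4 of the 4 values shown sit.

The compounds shown leave open whether any substituent on the shared core gives a measurable cytotoxic potency in this assay.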